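The source may report more compounds than this note shows. Statements on the series, on what has been measured and on what is new or still open speak of the compounds shown alone.

Compound 1 `Nc1scc(CN2CCN(c3ccc([N+](=O)[O-])cc3)CC2)c1C(=O)c1ccc(Cl)cc1` carries a 4-nitrophenyl on an amine nitrogen in a ring, and in a functional assay on CHO cells with adenosine receptor A1 (Homo sapiens) as the target, read by cAMP accumulation and immunoassay, with a stated time of 6 min, tested at 10 uM (a lower number here means a stronger effect, a higher number a weaker effect of the compound at the concentration tested), compound 1 gives -17%. Compound 2 `Nc1scc(CN2CCN(c3c(F)cccc3F)CC2)c1C(=O)c1ccc(Cl)cc1` bears a 2,6-difluorophenyl at that same nitrogen, and in this assay compound 2 gives -80%. For the measured compounds named here, the one measured step, a number 63 percentage points lower from compound 1 to compound 2 (beyond the scatter), shows that the group on this nitrogen moves the read-out strongly. Of the two numbers shown, compound 2 stands lowest, with compound 1 its nearest neighbour and beyond the scatter.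

Compound 3 `Nc1scc(CN2CCN(c3cccc(Cl)c3)CC2)c1C(=O)c1ccc(Cl)cc1` has not yet been measured; it differs from compound 2 in 3-chlorophenyl in place of 2,6-difluorophenyl on an amine nitrogen in a ring. Going by the values given here, the only step that bears on this change is a number 63 percentage points lower from compound 1 to compound 2 (beyond the scatter), which concerns the same position but another pair of groups. It shows that such a swap can move the number by a large amount, but gives no direct guide for 3-chlorophenyl. Because compound 2 sits at -80%, an upward step of moderate size, a number 30 percentage points higher from compound 2 to compound 3 (beyond the scatter), is expected. Compound 3 is therefore estimated to give -50%, within a range from -85% to -10%.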

Compound 3, a percentage reported as activity, at one concentration (the size of the read-out at that concentration, not a potency): -77%
For compound 3 the middle estimate is 27 percentage points above the measured one; the measured number falls inside the stated range.
By their numbers in this assay, from the lowest: compounds 2 and 3 (each within the scatter of the next); then compound 1.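

In this assay the exchange of 2,6-difluorophenyl for 3-chlorophenyl on the amine nitrogen gives a number 3 percentage points higher from compound 2 to compound 3 (within the scatter) and so shows that, among these groups, the kind of halogen, the number of halogens and where they sit on the phenyl ring can all differ with no difference that can be told apart in this read-out. The large shift seen earlier is therefore not particular to 2,6-difluorophenyl, since a number 60 percentage points lower from compound 1 to compound 3 (beyond the scatter) is of much the same size, which leaves the 4-nitrophenyl of compound 1 apart from the two halogen-bearing groups. No measurement at hand explains why these two groups read alike or why 4-nitrophenyl reads differently.

With only three aryl groups shown, it remains open whether an unsubstituted phenyl, a methoxyphenyl or a benzyl on this nitrogen would read with the two halogen-bearing groups or with 4-nitrophenyl. A read-out at a single concentration also leaves open whether compound 2 and compound 3 would still read alike across a range of concentrations.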